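A few compounds are considered here, and "the series" means these few. Any claim that something is new, unique, unknown or untested is made for them only; others in the source may bear on it.

Measured compounds:
- Compound 1, `COc1nc(CC(O)(CO)CO)c(C)c(OC)n1`: in a functional assay on MIA PaCa-2 cells (Homo sapiens) for antiproliferative activity, read by MTT assay, with a stated time of 72 h (a higher number here means a weaker inhibitor, a lower number a stronger inhibitor), compound 1 gives > 100000 nM, which is a limit of the assay rather than a number.
- Compound 2, `COc1nc(=O)n(C)c(CC(O)(COCc2ccccc2)COCc2ccccc2)c1C`: in this assay compound 2 gives 33500 nM.
- Compound 3, `CC(=O)OCC(O)(COC(C)=O)Cc1c(C)c(=O)[nH]c(=O)n1C`: in this assay compound 3 gives > 100000 nM, again a limit of the assay.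

Compound 3 thus stands at the limit of > 100000 nM in this assay, at which 2 of the 3 values shown sit; no number is known for it, only that limit. Compound 4, `CC(=O)OCC(F)(COC(C)=O)Cc1c(C)c(=O)[nH]c(=O)n1C`, has not yet been measured in this assay. It differs from compound 3 by fluoro in place of hydroxy on a saturated chain carbon bound to three saturated chain carbons. Going by the values given here, no measured pair shows this change, so the size of the step is untested. Starting from a compound already at a limit, the expected step of a number no higher from compound 3 to compound 4 (the limit leaves the size open) is none beyond the scatter. For compound 4 the expected value in this assay is 100000 nM, between 25000 nM and 300000 nM, most probably reported only as a limit again.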

Compound 4, half-maximal inhibitory concentration: > 100000 nM
Compound 4: a limit, no number; the forecaster's own chance of this, stated with the estimate: 75%; the middle value lies on the limit itself.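

Compound 3 and compound 4 each give only a limit of the assay, and no step can be read between them. Going by these compounds, whether fluoro in place of hydroxy on a saturated chain carbon bound to three saturated chain carbons alters the result in this assay stays open.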